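Aromatic group exchange from compound 3 to compound 4

The source may report more compounds than this note shows. Statements on the series, on what has been measured and on what is new or still open speak of the compounds shown alone.

Measured in a functional assay on CNE-2 cells (Homo sapiens) for inhibition, read by MTT assay, with a stated time of 72 h; on this read-out lower numbers stand for stronger inhibition and higher numbers for weaker inhibition:
- compound 1 `CNC(=O)CCCCCCCn1nc(-c2cnc3[nH]ccc3c2)c2c(N)ncnc21`: 8990 nM
- compound 2 `Nc1ncnc2c1c(-c1cnc3[nH]ccc3c1)nn2CCCCCCCCC(=O)NO`: 2270 nM
- compound 3 `Nc1nc2cc(-c3nn(CCCCCCCCCC(=O)NO)c4ncnc(N)c34)ccc2o1`: 36800 nM

Compound 3 has the highest number of the three. Compound 4 `Nc1ncnc2c1c(-c1cnc3[nH]ccc3c1)nn2CCCCCCCCCC(=O)NO` differs from it as follows: a group of 9 heavy atoms (7 carbon, 2 nitrogen; one five-membered aromatic ring with 1 hetero atom, one six-membered aromatic ring with 1 hetero atom) in place of a group of 10 heavy atoms (7 carbon, 2 nitrogen, 1 oxygen; one five-membered aromatic ring with 2 hetero atoms, one six-membered aromatic ring of carbon only), on an aromatic carbon. The group that leaves is 2-amino-1,3-benzoxazol-5-yl.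

Among the measured compounds shown here, no measured step isolates this exchange. The only one available, a 4.0-fold lower number from compound 1 to compound 2 (0.60 log units; beyond the scatter), is modest and concerns the chain end, which compound 3 and compound 4 share, so it bears only indirectly. The chain of compound 4 differs from that of compound 2, but the closest evidence is compound 2, which carries the entering group and gives 2270 nM. A large move toward lower numbers is therefore expected, estimated as an 11-fold lower number from compound 3 to compound 4 (1.02 log units; beyond the scatter). The expected value for compound 4 is 3500 nM, with an estimated range of 900 nM to 14000 nM.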

Compound 4, half-maximal inhibitory concentration: 2200 nM
Beside the measured number, compound 4's estimate is 1.6-fold (0.20 log units) above it; low and high end bracket the measured number.
By their numbers in this assay, from the lowest: compounds 4 and 2 (each within the scatter of the next); then compound 1; then compound 3.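

In this assay, the exchange on the aromatic carbon of the five-membered aromatic ring with 2 nitrogen gives a 17-fold lower number from compound 3 to compound 4 (1.22 log units; beyond the scatter) with the chain unchanged, so this position responds strongly to the loss of 2-amino-1,3-benzoxazol-5-yl. The chain counts for much less in this pair: a 1.0-fold lower number from compound 2 to compound 4 (0.01 log units; within the scatter) leaves the two hydroxycarbamoyl chains unseparated, while a 4.1-fold lower number from compound 1 to compound 4 (0.61 log units; beyond the scatter) keeps the methylcarbamoyl compound apart from compound 4 by a modest margin. No measured data accounts for the size of the aromatic group exchange.

Which part of the entering group carries the gain stays open, and a plain phenyl or an indol-5-yl at this position would test it. On these data alone, whether a carboxylic acid in place of the hydroxycarbamoyl end keeps these values is also open.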